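This account rests on a few compounds, and the source may have more. Where it says the series, first, only, none or still open, it means among the compounds named here.

Compound 2 `O=C(CN1CCN(c2nnc(Cc3ccncc3)c3ccccc23)CC1)Nc1c(F)cccc1F` stands at the higher of the two numbers gathered so far: in a functional assay on A549 cells (Homo sapiens) for cytotoxicity, read by MTT assay, with a stated time of 72 h (a lower number here means a stronger inhibitor, a higher number a weaker inhibitor), compound 2 gives 54400 nM. Going by the values given here, its only neighbour, compound 1 `O=C(CN1CCN(c2nnc(Cc3ccncc3)c3ccccc23)CC1)Nc1ccc(F)c(Cl)c1`, gives 12300 nM in this assay, and the single recorded step is a 4.4-fold higher number from compound 1 to compound 2 (0.65 log units; beyond the scatter). Compound 3 `Cc1cccc(Cl)c1NC(=O)CN1CCN(c2nnc(Cc3ccncc3)c3ccccc23)CC1` differs from compound 2 in one place: 2-chloro-6-methylphenyl in place of 2,6-difluorophenyl on an amide-type nitrogen. Among the compounds with values here, the one step that bears on this exchange on the amide-type nitrogen moved the number by a modest amount, but it compared a different pair of rings, so it gives only a rough sense of the size to expect here. A step of about a 1.6-fold lower number from compound 2 to compound 3 (0.19 log units; within the scatter) is therefore expected, toward a somewhat lower number, though a result within the scatter would not surprise. Compound 3 is estimated at 35000 nM in this assay, with a range from 12000 nM to 100000 nM.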

Compound 3, half-maximal inhibitory concentration: 7190 nM
Beside the measured number, compound 3's estimate is 4.9-fold (0.69 log units) above it; the whole stated range lies above it.
By their numbers in this assay, from the lowest: compounds 3 and 1 (each within the scatter of the next); then compound 2.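

On the amide-type nitrogen, 2-chloro-6-methylphenyl in place of 2,6-difluorophenyl gives a 7.6-fold lower number from compound 2 to compound 3 (0.88 log units; beyond the scatter) in this assay, so these two rings need not give similar numbers. Against the other ring, the exchange gives a 1.7-fold lower number from compound 1 to compound 3 (0.23 log units; within the scatter), so 2-chloro-6-methylphenyl and 3-chloro-4-fluorophenyl cannot be told apart here, and compound 2 stands alone as the weakest of the three, something the first pair could not show. Nothing available explains why these rings differ. Going by these compounds, it remains open whether the chlorine or the methyl of compound 3 accounts for the step, a question that 2,6-dichlorophenyl and 2,6-dimethylphenyl on the same nitrogen would separate. Also open, on these data alone, is how an unsubstituted phenyl or a pyridyl ring would compare at this position.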